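The compounds below may be only part of what the source reports. "The series", "measured", "known", "first", "only" and "open" are said of these compounds alone.

Compound 1 `O=C(/C=C/c1ccc(OCCCCCO[N+](=O)[O-])c(O)c1)OCCCCCO[N+](=O)[O-]` carries two nitrate ester chains, one on the ester and one on the ring oxygen, and a free hydroxy on the aromatic ring. In a functional assay on Calu-1 cells (Homo sapiens) for cytotoxicity, read by resazurin assay, with a stated time of 72 h (a higher number here means a weaker inhibitor, a lower number a stronger inhibitor), compound 1 gives only a limit, > 50000 nM. Compound 3 `COc1cc(/C=C/C(=O)OCCCCCO[N+](=O)[O-])ccc1OCCCCCO[N+](=O)[O-]` differs from compound 1 by methyl in place of hydrogen on an oxygen on an aromatic ring. In this assay compound 3 likewise gives only a limit, > 50000 nM. The step that the two limits leave unreadable from compound 1 to compound 3 therefore cannot be read, because of the limit of > 50000 nM in this assay, at which 3 of the 3 values shown sit.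

Compound 2 `O=C(/C=C/c1ccc(OCCCCO[N+](=O)[O-])c(O)c1)OCCCCO[N+](=O)[O-]` shares the free hydroxy of compound 1 but has shorter chains; the difference between the two cores is not broken down here. In this assay compound 2 gives only a limit, > 50000 nM.

Compound 4 `COc1cc(/C=C/C(=O)OCCCCO[N+](=O)[O-])ccc1OCCCCO[N+](=O)[O-]` has not yet been measured. It differs from compound 2 by methyl in place of hydrogen on an oxygen on an aromatic ring, the same change that leads from compound 1 to compound 3. Among the compounds with values here, since all three measured compounds sit at the same limit and the one measured instance of this change left no readable step, the expected step from compound 2 to compound 4 in this assay is a step that the limit leaves unreadable from compound 2 to compound 4, meaning no departure from the limit is anticipated. Compound 4 is accordingly expected to give about 80000 nM, most likely again reported only as a limit, with a plausible range from 40000 nM to 200000 nM.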

Compound 4, half-maximal inhibitory concentration: > 50000 nM
Compound 4 ended at the assay's limit; the forecaster's own chance of this, stated with the estimate: 85%; the middle value does not contradict the limit.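

Compound 4, like compound 2, gives only a limit in this assay, so no step can be read between compound 2 and compound 4, because neither value is a number: (the limit of > 50000 nM in this assay, at which 4 of the 4 values shown sit). The four compounds shown leave open how strong any of them is in this assay, and whether going from hydroxy to methoxy or changing the chains has any effect there.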